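A few compounds are considered here, and "the series" means these few. Any claim that something is new, unique, unknown or untested is made for them only; others in the source may bear on it.

Measured in a physicochemical assay for solubility; on this read-out higher numbers stand for higher solubility and lower numbers for lower solubility:
Compound 1 `CNC(=O)c1cc(C(=O)N[C@H]2[C@@H]3COC[C@@H]32)cc2c1OC[C@H]2c1cccnc1`: >= 104 ug/mL
Compound 2 `CC[C@@]1(c2ccccc2)COc2c(C(=O)NC)cc(C(=O)N[C@H]3[C@@H]4COC[C@@H]43)cc21`: >= 152 ug/mL
Compound 3 `CNC(=O)c1cc(C(=O)NC2CC2)cc2c1OC[C@H]2c1cccc(F)c1`: >= 175 ug/mL

Each of these three entries is a limit of the assay and not a number. In this assay, compound 3 thus stands only at its limit of >= 175 ug/mL. For the measured compounds named here, no two measured compounds differ in just one place, so the data give no direct size for a step. Compound 4 `CNC(=O)c1cc(C(=O)NC2CC2)cc2c1OC[C@H]2c1ccccc1` carries hydrogen in place of fluoro on an aromatic carbon, turning 3-fluorophenyl into phenyl. The expectation rests on compound 3 and its limit of >= 175 ug/mL. The estimated step that the limit leaves unreadable from compound 3 to compound 4 is expected to stay within the usual scatter, with no direction favoured. For compound 4 the expected value is 180 ug/mL, with an estimated range of 100 ug/mL to 350 ug/mL.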

Compound 4, solubility: >= 190 ug/mL
Compound 4: no number, only a limit; the forecaster's own chance of this, stated with the estimate: 70%; middle value at least 1.0-fold (0.02 log units) from the limit.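

Compound 3 and compound 4 stand only as limits in this assay, and the step between them cannot be read. The compounds shown leave open whether hydrogen in place of fluoro on an aromatic carbon shifts this read-out at all, and in which direction.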